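Dibenzoylhydrazine series: chain length at the acyl side

This account rests on a few compounds, and the source may have more. Where it says the series, first, only, none or still open, it means among the compounds named here.

Measured so far in an assay on cells for agonist activity at ecdysone receptor (Bombyx mori), read by a luciferase reporter, with a stated time of 24 h; a higher number here means that more compound is needed for the effect, a lower number that less compound is needed:
compound 1 `Cc1cc(C)cc(C(=O)N(NC(=O)c2ccc(Cl)cc2)C(C)(C)C)c1`: 19.1 nM
compound 2 `CCCCCC(=O)NN(C(=O)c1cc(C)cc(C)c1)C(C)(C)C`: 79.4 nM
compound 3 `Cc1cc(C)cc(C(=O)N(NC(=O)CCC(C)C)C(C)(C)C)c1`: 91.2 nM

Compound 3 stands at the high end of the three numbers in this assay. Its nearest neighbour is compound 2, with a 1.1-fold higher number from compound 2 to compound 3 (0.06 log units; within the scatter); the gap to compound 1 is the widest, with a 4.8-fold higher number from compound 1 to compound 3 (0.68 log units; beyond the scatter). The two aliphatic acyl groups thus sit together, and both are set apart from the aryl acyl of compound 1, as a 4.2-fold higher number from compound 1 to compound 2 (0.62 log units; beyond the scatter) also shows.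

Compound 4 `CCCCCCCCCC(=O)NN(C(=O)c1cc(C)cc(C)c1)C(C)(C)C` differs from compound 3 by heptyl in place of isopropyl on a saturated chain carbon, two bonds along the chain from a carbonyl carbon. Going by the values given here, the only measured step that touches the same place is the one from compound 2 to compound 3, a reshuffle of the same number of chain carbons, and it lay within the scatter. Among the compounds with values here, no measured pair shows what a much longer chain does; the data give no precedent for it. The working expectation is therefore a small step in this assay, if any, perhaps towards a somewhat higher number, with wide uncertainty.

Compound 4 is estimated at 150 nM, with a range from 50 nM to 500 nM, which is expected to mean a 1.6-fold higher number from compound 3 to compound 4 (0.22 log units; within the scatter).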

Compound 4, half-maximal effective concentration: 1550 nM
Compound 4: middle estimate off by 10-fold (1.01 log units), on the low side, and the stated range ends below it.
By their numbers in this assay, from the lowest: compound 1; then compounds 2 and 3 (each within the scatter of the next); then compound 4.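

The long-chain end of this position does not behave like the short-chain end: in this assay the step of a 17-fold higher number from compound 3 to compound 4 (1.23 log units; beyond the scatter) for heptyl in place of isopropyl and the step of a 20-fold higher number from compound 2 to compound 4 (1.29 log units; beyond the scatter) for butyl in place of hydrogen on a saturated chain carbon, five bonds along the chain from a carbonyl carbon, both dwarf the step of a 1.1-fold higher number from compound 2 to compound 3 (0.06 log units; within the scatter) that lies within the scatter. Going by these compounds alone, the earlier compounds showed only that the aliphatic acyl groups sat close together, and the nonyl chain of compound 4 shows that this closeness does not hold for every aliphatic chain. Against the 4-chlorophenyl of compound 1 the gap also widens to the step of an 81-fold higher number from compound 1 to compound 4 (1.91 log units; beyond the scatter) for nonyl, well past the step of a 4.2-fold higher number from compound 1 to compound 2 (0.62 log units; beyond the scatter) for pentyl, and no supporting data bear on what lies behind this loss.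

The compounds shown leave open where between the pentyl of compound 2 and the nonyl of compound 4 the number begins to rise, as a hexyl or heptyl group in the same place would tell. They also leave open how a chain carrying a carboxylic acid or an amine would read here.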